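Swapping tert-butyl for tert-butoxycarbonyl: expected half-life

The source may report more compounds than this note shows. Statements on the series, on what has been measured and on what is new or still open speak of the compounds shown alone.

Measured so far:
- compound 1, `CC(C)/N=C(\NC1=NC(=O)CN1c1ccc(Cl)c(Cl)c1)Nc1ccc(Cl)c(Cl)c1`, 0.654 h
- compound 2, `CC(C)N1CC(=O)N=C1N/C(=N\C(C)(C)C)Nc1ccc(Cl)c(Cl)c1`, 0.662 h
- compound 3, `CC(C)N1CC(=O)N=C1N/C(=N/c1ccc(Cl)c(Cl)c1)N1CCCCC1`, 0.467 h

Of the compounds shown here, three built on a shared core have been tested in an in vivo ADME assay on the whole organism for metabolic stability, with Homo sapiens as the target, read by LC-MS, at a dose of 160 mg/kg by the oral route; on this read-out lower numbers stand for a shorter-lived compound and higher numbers for a longer-lived compound. Compound 1 gives 0.654 h, compound 2 gives 0.662 h and compound 3 gives 0.467 h. All three numbers lie within the usual scatter of one another, so the data so far do not separate the compounds: compound 2 sits close to compound 1 and also close to compound 3, with no difference that can be trusted.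

Compound 4, `CC(C)N1CC(=O)N=C1N/C(=N\C(=O)OC(C)(C)C)Nc1ccc(Cl)c(Cl)c1`, has not yet been measured in this assay. It differs from compound 2 in one place: tert-butoxycarbonyl in place of tert-butyl on a double-bonded nitrogen. In words, a tert-butoxycarbonyl takes the place of a tert-butyl on a double-bonded nitrogen.

Among the compounds with values here, no step between two measured compounds covers this change, so there is no measured precedent for its size or direction. With the three known values all falling within the scatter, the expectation for compound 4 is a step from compound 2 of a 1.1-fold lower number from compound 2 to compound 4 (0.04 log units; within the scatter), that is, no change beyond the scatter. Compound 4 is therefore estimated to give 0.6 h in this assay, with a likely range from 0.3 h to 1.2 h.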

Compound 4, half-life: 0.213 h
Estimate against measurement, compound 4: 2.8-fold (0.45 log units) above, and the stated range ends above it.
By their numbers in this assay, from the lowest: compound 4; then compounds 3, 1 and 2 (each within the scatter of the next).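

In this assay, the group on this double-bonded nitrogen proves able to shift the half-life, with tert-butoxycarbonyl in place of tert-butyl giving a 3.1-fold lower number from compound 2 to compound 4 (0.49 log units; beyond the scatter). Within the data shown here, compound 1, compound 2 and compound 3 could not show this, as their numbers all lie within the scatter of one another, so this is the first sign that a change here can separate two compounds. The swap alters several things at once, since the entering group has more heavy atoms, a double bond and two hydrogen-bond acceptors, and nothing available here shows which of these features, if any, accounts for the shorter half-life.

Among these compounds, with only one step at this position, it remains open whether the shorter half-life goes with the carbonyl as such or needs the whole tert-butoxycarbonyl group. An acetyl group on the same nitrogen would keep the carbonyl without the tert-butyl part and could help to tell these apart, and whether the same swap has a similar effect on other members of the series is also unknown.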